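The source may report more compounds than this note shows. Statements on the series, on what has been measured and on what is new or still open speak of the compounds shown alone.

Compound 1 `COc1ccccc1C(=O)Nc1cccc(NC(=O)c2ccc(F)cc2)c1`: > 30000 nM
Compound 2 `O=C(Nc1cccc(O)c1)c1cccc(N2C(=O)c3ccccc3C2=O)c1`: 7790 nM

In an in vitro functional assay on HEK293-A cells for antagonist activity at metabotropic glutamate receptor 5 (Rattus norvegicus), read by calcium flux (a lower number here means a stronger inhibitor, a higher number a weaker inhibitor), compound 1 gives only a limit, > 30000 nM, with no exact number. Among the measured compounds shown here, compound 2 gives 7790 nM in this assay, the single numerical value among the two results, and a weak one. Compound 3 `O=C(Nc1ccccc1F)c1cccc(N2C(=O)c3ccccc3C2=O)c1` differs from compound 2 by one change: 2-fluorophenyl in place of 3-hydroxyphenyl on an amide-type nitrogen. For the measured compounds named here, no measured pair shows this change, so the expected step is an estimate only. A modest weakening, roughly on the edge of the usual scatter, is expected: a 1.9-fold higher number from compound 2 to compound 3 (0.28 log units; within the scatter). Compound 3 is estimated at 15000 nM, most likely between 4000 nM and 40000 nM.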

Compound 3, half-maximal inhibitory concentration: 1050 nM
For compound 3 the middle estimate is 14-fold (1.15 log units) above the measured one; the whole stated range lies above it.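

In this assay, putting 2-fluorophenyl in place of 3-hydroxyphenyl on the amide-type nitrogen gives a 7.4-fold lower number from compound 2 to compound 3 (0.87 log units; beyond the scatter), so the group at this position clearly matters for inhibition. Compound 3 also shows that the hydroxyl group is not required for activity here, as it carries no hydrogen-bond donor on this ring and is still the stronger inhibitor of the pair. Nothing shown here explains why the step occurs. The swap removes the hydroxyl group, adds fluorine and changes the substituent's place on the ring, and this one pair cannot separate those changes. Plain phenyl and 3-fluorophenyl would be needed to tell how much each contributes.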